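Removing a methoxy from the weak dimethoxy analogue

The source may report more compounds than this note shows. Statements on the series, on what has been measured and on what is new or still open speak of the compounds shown alone.

Measured in a functional assay on MCF7 cells (Homo sapiens) for cytotoxicity, read by sulforhodamine B assay, with a stated time of 48 h; on this read-out higher numbers stand for weaker inhibition of growth and lower numbers for stronger inhibition of growth:
compound 1 `COc1ccc(/C(Cl)=C/C=C(\C#N)C(=O)c2c(C)[nH]c3ccccc23)cc1OC` gives 29600 nM
compound 2 `COc1cc(/C(Cl)=C/C=C(\C#N)C(=O)c2c(C)[nH]c3ccccc23)cc(OC)c1OC` gives < 100 nM (a limit of the assay, not a number)
compound 3 `COc1cc(/C(Cl)=C/C=C(\C#N)C(=O)c2c[nH]c3ccc(Br)cc23)cc(OC)c1OC` gives 30800 nM

Compound 1 stands at the lowest of the two numbers given; compound 3 sits at a gap from it that is within the scatter, so the two cannot be ordered. Compound 2 reports only a limit, (the limit of < 100 nM in this assay, at which 1 of the 3 values shown sits).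

The unmeasured compound 4 `COc1ccc(/C(Cl)=C/C=C(\C#N)C(=O)c2c(C)[nH]c3ccccc23)cc1` differs from compound 1 by one change: hydrogen in place of methoxy on an aromatic carbon.

Within the data shown here, only one measured step touches the methoxy pattern on this ring: an at least 290-fold lower number from compound 1 to compound 2 (2.47 log units; beyond the scatter), where a methoxy entered on an aromatic carbon and the number fell sharply. The step to compound 4 goes the other way, taking a methoxy off, so the expectation is no gain and more likely a further rise in the number, though how far is uncertain since compound 1 is already weak. The step of an at least 300-fold higher number from compound 2 to compound 3 (2.48 log units; beyond the scatter) changes the other end of the core and does not bear on this question.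

For compound 4 the estimate in this assay is 45000 nM (range 15000 nM to 130000 nM), meaning an expected step of a 1.5-fold higher number from compound 1 to compound 4 (0.18 log units; within the scatter) that may well stay within the scatter.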

Compound 4, concentration for 50% growth inhibition: 56700 nM
The estimate for compound 4 lay 1.3-fold (0.10 log units) below the measured number; measured number inside the range.
By their numbers in this assay, from the lowest: compounds 1, 3 and 4 (each within the scatter of the next). At a limit, below all of these: compound 2.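

In this assay, taking off the methoxy that sits ortho to a methoxy group and meta to a large group gives a 1.9-fold higher number from compound 1 to compound 4 (0.28 log units; within the scatter), so on the background of compound 1 this change produces no difference that can be read. The earlier compounds shown here showed only the opposite kind of change on this ring, a methoxy entering with an at least 290-fold lower number from compound 1 to compound 2 (2.47 log units; beyond the scatter); with the new step lying within the scatter and that one beyond it, the number of methoxy groups does not track the read-out evenly across compounds 4, 1 and 2. Compound 2 is reported as a limit and not a number, so the full size of its step stays unknown: the limit of < 100 nM in this assay, at which 1 of the 4 values shown sits.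

The compounds shown leave open whether this methoxy matters on the background of compound 2, where the read-out is far stronger, since the new step was read only on a weak background. They also leave open how this position would respond to a group other than methoxy or hydrogen, such as a hydroxyl, an amine or a fluorine.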